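Compound 3: 2-chlorophenyl in place of 4-chlorophenyl

The source may hold more compounds than are shown below. What is called first, only, known or untested is meant among the compounds shown, and "the series" means these compounds.

Measured in a functional assay on EC9706 cells (Homo sapiens) for cytotoxicity, read by MTT assay, with a stated time of 72 h; a lower number here means a stronger inhibitor, a higher number a weaker inhibitor:
Compound 1 `O=C(CCl)Nc1ccc(C(=O)/C=C/c2ccc(Cl)cc2)cc1`: 8340 nM
Compound 2 `O=C(CSC(=S)N[C@H]1CCOC1=O)Nc1ccc(C(=O)/C=C/c2ccc(Cl)cc2)cc1`: 38900 nM

Compound 2 has the higher of the two numbers, which marks it as the weaker inhibitor so far. Compound 3 `O=C(CSC(=S)N[C@H]1CCOC1=O)Nc1ccc(C(=O)/C=C/c2ccccc2Cl)cc1` differs from it in one place: 2-chlorophenyl in place of 4-chlorophenyl on a double-bonded chain carbon bound to a double-bonded chain carbon. Going by the values given here, the only measured step, a 4.7-fold higher number from compound 1 to compound 2 (0.67 log units; beyond the scatter), lies at a different place, on a saturated chain carbon bound to a carbonyl carbon. Among the compounds with values here, it gives no direct guide here, and no measured pair changes the chlorophenyl group. No step beyond the scatter is therefore expected in this assay, and no direction is favoured with confidence. The expected change is a 1.3-fold lower number from compound 2 to compound 3 (0.11 log units; within the scatter). Compound 3 is estimated at 30000 nM, with an expected range of 12000 nM to 75000 nM.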

Compound 3, half-maximal inhibitory concentration: 34100 nM
Compound 3: middle estimate off by 1.1-fold (0.06 log units), on the low side, within the range that was stated.
By their numbers in this assay, from the lowest: compound 1; then compounds 3 and 2 (each within the scatter of the next).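

In this assay, going by these compounds alone, the first change at this place gives a 1.1-fold lower number from compound 2 to compound 3 (0.06 log units; within the scatter). With the rest of compound 2 held fixed, 2-chlorophenyl and 4-chlorophenyl on a double-bonded chain carbon are therefore not told apart, unlike the step beyond the scatter at the saturated chain carbon. No measurement at hand offers an explanation of this result. Open, on these data alone, is whether a methoxyphenyl or an aminophenyl group in place of the chlorophenyl group would shift the number. Also open, as far as these compounds go, is whether 2-chlorophenyl would behave alike on compound 1.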